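A Pyrrolidinyl Carbonyl Group on Compound 3

The source may hold more compounds than are shown below. What is called first, only, known or untested is meant among the compounds shown, and "the series" means these compounds.

Three related compounds have been read in a functional assay on RAW264.7 cells (Mus musculus) for inhibition, read by Griess assay, with stated times of 3 h and 24 h (on this read-out lower numbers stand for stronger inhibition and higher numbers for weaker inhibition), and none has yet given a number. Compound 1 (`C=C1CC[C@H]2[C@@](C)(CCC(=O)N[C@@]2(C)CO)[C@@H]1/C=C/C1=CCOC1=O`) gives > 50000 nM, which is a limit of the assay. Compound 2 (`C=C1CC[C@H]2[C@@](C)(CCC(=O)N[C@@]2(C)COC(=O)[C@H](N)CC(C)C)[C@@H]1/C=C/C1=CCOC1=O`) gives > 50000 nM, which is also a limit. Compound 3 (`C=C1CC[C@H]2[C@@](C)(CC[C@@H](O)[C@@]2(C)NC=O)[C@@H]1/C=C/C1=CCOC1=O`) gives > 50000 nM, again a limit and not a number. Compound 3 therefore stands with the other two, as the limit of > 50000 nM in this assay, at which 3 of the 3 values shown sit, shows.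

Compound 4 (`C=C1CC[C@H]2[C@@](C)(CC[C@@H](OC(=O)[C@H]3CCCN3)[C@@]2(C)NC=O)[C@@H]1/C=C/C1=CCOC1=O`) is compound 3 with a single change: (pyrrolidin-2-yl)carbonyl in place of hydrogen on an oxygen on a saturated carbon. In words, (pyrrolidin-2-yl)carbonyl comes in place of hydrogen on an oxygen on a saturated carbon, so that hydroxy becomes ((pyrrolidin-2-yl)carbonyl)oxy.

For the measured compounds named here, one measured step bears on this change: a step that the two limits leave unreadable from compound 1 to compound 2, where (1-amino-3-methylbutyl)carbonyl came in place of hydrogen on an oxygen on a saturated carbon. Both ends of that step are limits, so it has no readable size and offers no evidence of a gain in this assay. The expected outcome is a number no higher from compound 3 to compound 4 (the limit leaves the size open), with no direction expected beyond the scatter. Compound 4 is expected to remain near the limit, with an estimate of 50000 nM and an estimated range from 25000 nM to 100000 nM.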

Compound 4, half-maximal inhibitory concentration: > 50000 nM
Compound 4: no number, only a limit; the forecaster's own chance of this, stated with the estimate: 80%; the middle value sits exactly at the limit.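

In this assay compound 4 gives > 50000 nM, which is a limit and not a number. The step from compound 3 to compound 4 cannot be read, as both ends are limits, and the four compounds now stand together: the limit of > 50000 nM in this assay, at which 4 of the 4 values shown sit.

The compounds shown leave open what real value any of them has in this assay, and whether (pyrrolidin-2-yl)carbonyl in place of hydrogen changes it.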